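Moving the nitro group on compound 3

This account rests on a few compounds, and the source may have more. Where it says the series, first, only, none or still open, it means among the compounds named here.

In a functional assay on RS4-11 cells (Homo sapiens) for inhibition, read by CCK-8 assay, with a stated time of 48 h, tested at 20 uM (on this read-out higher numbers stand for more inhibition of growth at the one concentration tested and lower numbers for less inhibition of growth), compound 3 `N#C/C(=C\c1ccccc1OS(=O)(=O)c1ccc([N+](=O)[O-])cc1)C(=O)Nc1nnc(Cc2cccc3ccccc23)s1` gives 58%. That lies within the usual scatter of compound 1 `COc1ccc(Cc2nnc(NC(=O)/C(C#N)=C/c3ccccc3OS(=O)(=O)c3ccccc3[N+](=O)[O-])s2)cc1` at 68%, while compound 2 `Cc1ccc(S(=O)(=O)Oc2ccccc2/C=C(\C#N)C(=O)Nc2nnc(Cc3cccc4ccccc34)s2)cc1` at 73% stands higher, beyond the scatter. Compound 4 `N#C/C(=C\c1ccccc1OS(=O)(=O)c1ccccc1[N+](=O)[O-])C(=O)Nc1nnc(Cc2cccc3ccccc23)s1` has the same atoms joined differently: 2-nitrophenyl in place of 4-nitrophenyl on a sulfonyl sulfur. Within the data shown here, no measured step makes this exact change. The nearest, a number 15 percentage points lower from compound 2 to compound 3 (beyond the scatter), was modest and swapped a different group. Compound 1, which carries 2-nitrophenyl but differs elsewhere, gives 68%, so little change seems likely. The expected change is a number 4 percentage points higher from compound 3 to compound 4 (within the scatter), which stays within the scatter. Compound 4 is estimated at 62%, with an expected range from 48% to 76%.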

Compound 4, percent growth inhibition at one concentration: 66%
Compound 4: the middle estimate sits 4 percentage points below what was measured, within the range that was stated.
By their numbers in this assay, from the lowest: compounds 3, 4, 1 and 2 (each within the scatter of the next, the first and the last beyond it).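

In this assay, 2-nitrophenyl and 4-nitrophenyl on the sulfonyl sulfur cannot be told apart, with a number 8 percentage points higher from compound 3 to compound 4 (within the scatter). Unlike 4-nitrophenyl, 2-nitrophenyl stays within the scatter of 4-methylphenyl, with a number 7 percentage points lower from compound 2 to compound 4 (within the scatter), and the naphthalen-1-yl and 4-methoxyphenyl groups cannot be separated with 2-nitrophenyl in place, with a number 2 percentage points lower from compound 1 to compound 4 (within the scatter). No measurement available here explains these results.

The compounds shown leave open how an amine or a carboxylic acid on that phenyl ring, in place of the nitro group, would read. They also leave open whether these close numbers would stay close at other concentrations.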